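A few compounds are considered here, and "the series" means these few. Any claim that something is new, unique, unknown or untested is made for them only; others in the source may bear on it.

Compound 1 `COc1cccc(OC)c1OCCNCCOc1ccccc1OCc1cccc(Cl)c1` is measured in an assay on CHO cells for displacement of a labelled ligand from Alpha-1B adrenergic receptor (Homo sapiens) (on this read-out higher numbers stand for weaker inhibition and lower numbers for stronger inhibition), where compound 1 gives 0.159 nM. Within the data shown here, its only measured partner is compound 2 `COc1cccc(OC)c1OCCNCCOc1ccccc1OCc1ccc(C)cc1`, which in this assay gives 0.251 nM. Compound 1 holds the lower of the two numbers, though the step of a 1.6-fold higher number from compound 1 to compound 2 (0.20 log units; within the scatter) lies within the scatter, so the two are not truly told apart. Compound 3 `COc1cccc(OC)c1OCCNCCOc1ccccc1OCc1ccccc1[N+](=O)[O-]` has not yet been measured in this assay. The change from compound 1 to compound 3 is 2-nitrophenyl in place of 3-chlorophenyl on a saturated chain carbon bound to an oxygen on an aromatic ring. Among the measured compounds shown here, the one measured step at that same place swapped the aromatic group there without moving the number beyond the scatter, and that is the only guide available. A similarly small step, with no clear direction, is therefore expected; for compound 3 the expected step is a 1.9-fold higher number from compound 1 to compound 3 (0.28 log units; within the scatter). On that basis compound 3 is estimated to give about 0.3 nM in this assay, within a range from 0.1 nM to 1 nM.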

Compound 3, inhibition constant: 2.51 nM
The estimate for compound 3 lay 8.4-fold (0.92 log units) below the measured number; the whole stated range lies below it.
By their numbers in this assay, from the lowest: compounds 1 and 2 (each within the scatter of the next); then compound 3.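

This position is not indifferent to what sits on it: the first swap stayed within the scatter, but 2-nitrophenyl gives a 16-fold higher number from compound 1 to compound 3 (1.20 log units; beyond the scatter) and a 10-fold higher number from compound 2 to compound 3 (1.00 log units; beyond the scatter) in this assay. So the number can shift well beyond the scatter through a change at this one place, and both 3-chlorophenyl and 4-methylphenyl give lower numbers than 2-nitrophenyl. Nothing shown here explains the rise.

Among these compounds, with only three groups compared, it stays open whether the higher number belongs to the nitro group itself or to where it stands on the ring, since 2-nitrophenyl differs from 3-chlorophenyl in both. Going by these compounds, how an unsubstituted phenyl ring, or a ring carrying a nitrile or a carboxylic acid, would behave at this place also remains unknown.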